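Trimethoxybenzoyl series: acetyl oxadiazoline with trifluoromethylphenyl

A few compounds are considered here, and "the series" means these few. Any claim that something is new, unique, unknown or untested is made for them only; others in the source may bear on it.

Three compounds of the series have numbers in a functional assay on PC-3 cells (Homo sapiens) for antiproliferative activity, read by MTT assay, tested at 1 uM; on this read-out lower numbers stand for a weaker effect and higher numbers for a stronger effect at the one concentration tested. Compound 1 `COc1ccc(/C=N/NC(=O)c2cc(OC)c(OC)c(OC)c2)c(OC)c1` gives 10%, compound 2 `COc1cc(C2=NN(C(C)=O)C(c3c(Cl)cccc3Cl)O2)cc(OC)c1OC` gives 5.1%, and compound 3 `COc1cc(C(=O)N/N=C/c2ccccc2C(F)(F)F)cc(OC)c1OC` gives 45%. Compound 2 sits at the bottom of the three values: its gap to compound 1 lies within the scatter, its gap to compound 3 beyond it. Compound 4 `COc1cc(C2=NN(C(C)=O)C(c3ccccc3C(F)(F)F)O2)cc(OC)c1OC` is not yet measured; it differs from compound 2 by 2-(trifluoromethyl)phenyl in place of 2,6-dichlorophenyl on a saturated ring carbon. Among the compounds with values here, no measured pair shows this change alone, and compound 3 carries the same 2-(trifluoromethyl)phenyl on an open core. An upward step is expected, though of uncertain size, and the estimate for compound 4 is 20%, between 5% and 45%, which means an expected step of a number 14.9 percentage points higher from compound 2 to compound 4 (beyond the scatter).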

Compound 4, a percentage reported as inhibition, at one concentration (the size of the read-out at that concentration, not a potency): -11%
For compound 4 the middle estimate is 31 percentage points above the measured one; measured number outside the range, below it.
By their numbers in this assay, from the lowest: compound 4; then compounds 2 and 1 (each within the scatter of the next); then compound 3.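

In this assay, the aryl group on the saturated ring carbon now has one readable single change: 2-(trifluoromethyl)phenyl in place of 2,6-dichlorophenyl gives a number 16.1 percentage points lower from compound 2 to compound 4 (beyond the scatter) on the shared acetyl-bearing core. This change does not raise the read-out here, and compound 4 stands at -11% in this assay, a value below zero. Nothing at hand accounts for this step. Still open, as far as these compounds go, is how a plain phenyl or an aminophenyl on this ring carbon would read. A single pair also leaves open whether a propionyl group in place of the acetyl group would alter this order.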